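Aromatase series: nitrophenoxy to formyl-methoxyphenoxy ether

The source may hold more compounds than are shown below. What is called first, only, known or untested is meant among the compounds shown, and "the series" means these compounds.

Compound 1 `COc1cc2c(cc1OC)CN(S(=O)(=O)c1ccc(-n3cc(COc4ccc([N+](=O)[O-])cc4)nn3)cc1)CC2` and compound 2 `O=c1cc(OCc2cn(-c3ccc(S(=O)(=O)N4CCc5ccccc5C4)cc3)nn2)c2ccccc2o1` share a sulfonyl-linked triazole bearing an aryloxymethyl group. In an assay on isolated protein for inhibition of Aromatase (Homo sapiens), read by fluorescence, with a stated time of 10 min (a lower number here means a stronger inhibitor, a higher number a weaker inhibitor), compound 1 gives 12500 nM, and compound 2 gives 12500 nM, so compound 1 stands level with compound 2 at the digits shown, within the scatter. For the measured compounds named here, no step between measured compounds that differ in one place is available, so nothing in the measured pair tells how the aryloxy group itself moves the read-out.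

Compound 3 `COc1cc2c(cc1OC)CN(S(=O)(=O)c1ccc(-n3cc(COc4cc(C=O)ccc4OC)nn3)cc1)CC2` is not yet measured. It differs from compound 1 by 5-formyl-2-methoxyphenyl in place of 4-nitrophenyl on an oxygen on a saturated carbon. With both measured compounds giving the same weak value despite unrelated aryloxy groups, the step from compound 1 to compound 3 is expected to be small, none beyond the scatter, as no change at the digits printed from compound 1 to compound 3 (within the scatter). For compound 3 the estimate in this assay is 12500 nM, ranging from 4000 nM to 40000 nM.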

Compound 3, half-maximal inhibitory concentration: 12500 nM
For compound 3 middle estimate and measured number coincide at the digits printed; the measured number falls inside the stated range.
By their numbers in this assay, from the lowest: compounds 1, 2 and 3 (each within the scatter of the next).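

In this assay, 5-formyl-2-methoxyphenyl in place of 4-nitrophenyl on an oxygen on a saturated carbon gives no change at the digits printed from compound 1 to compound 3 (within the scatter) and is the only step shown that isolates this position with the rest of the molecule held fixed. Across this pair, the read-out does not separate the two aryl groups, even though the nitro group gives way to formyl and methoxy groups. Nothing measured on these compounds accounts for the flat result.

As far as these compounds go, it remains open whether the read-out at this position would respond to a group of a different kind, such as a primary amine or a carboxylic acid on the ring, or a longer chain in place of the methylene link. From the compounds shown here alone, the effect of changing the shared core while keeping either aryloxy group also remains open.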